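Cyano on the Distal Phenyl: Compound 3 to Compound 4

The source may hold more compounds than are shown below. What is called first, only, known or untested is meant among the compounds shown, and "the series" means these compounds.

Measured so far:
- compound 1, `O=C(CCc1cccc2c1B(O)OC2)Nc1nccs1`: > 100000 nM
- compound 2, `COc1ccc(NC(=O)CCc2cccc3c2B(O)OC3)cc1`: 1700 nM
- compound 3, `O=C(CCc1cccc2c1B(O)OC2)Nc1cccc(-c2ccccc2)c1`: 890 nM

Of the compounds shown here, three sharing one core have been tested in a functional assay on HCT-116 cells (Homo sapiens) for antiproliferative activity, read by MTT assay, with a stated time of 72 h; a lower number here means a stronger inhibitor, a higher number a weaker inhibitor. Compound 1, `O=C(CCc1cccc2c1B(O)OC2)Nc1nccs1`, gives > 100000 nM, which is a limit of this assay and not a number. Compound 2, `COc1ccc(NC(=O)CCc2cccc3c2B(O)OC3)cc1`, gives 1700 nM in this assay. Compound 3, `O=C(CCc1cccc2c1B(O)OC2)Nc1cccc(-c2ccccc2)c1`, gives 890 nM in this assay, the lowest of the two numbers that were obtained; the gap to compound 2 lies within the scatter, so no order between compound 3 and compound 2 can be read from them.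

The next compound is compound 4, `N#Cc1ccc(-c2cccc(NC(=O)CCc3cccc4c3B(O)OC4)c2)cc1`, not yet measured in this assay. It differs from compound 3 in one place: cyano in place of hydrogen on an aromatic carbon.

Among the compounds with values here, no measured pair in this set isolates this kind of change, so there is nothing to set the size of the step against. The step expected in this assay from compound 3 to compound 4 is small, a 1.3-fold lower number from compound 3 to compound 4 (0.10 log units; within the scatter), and not beyond the scatter in either direction. Compound 4 is therefore estimated at 700 nM in this assay, with a range from 250 nM to 2500 nM.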

Compound 4, half-maximal inhibitory concentration: 410 nM
Beside the measured number, compound 4's estimate is 1.7-fold (0.23 log units) above it, and the stated range covers the measured number.
By their numbers in this assay, from the lowest: compound 4; then compounds 3 and 2 (each within the scatter of the next). At a limit, above all of these: compound 1.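

In this assay, within the data shown here, the change from phenyl to 4-cyanophenyl gives the first step in this set that can be read from a pair differing in one place: a 2.2-fold lower number from compound 3 to compound 4 (0.34 log units; beyond the scatter), a modest step that stands clear of the scatter. It shows that this aromatic carbon, para to a large group, takes a cyano group with no loss in this assay, and that a change at this one carbon is enough to move the number by a readable amount, although the step rests on this single pair. Nothing measured here speaks to why the cyano group has this effect.

The compounds shown leave open whether the step belongs to the cyano group itself or would also come with another group on this carbon, such as a chlorine atom, an amine or a carboxylic acid. They also leave open whether a cyano group on another carbon of the same ring would give a step of similar size, or whether the step would hold on a different cell line.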